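Amide swap on the carbonyl: outlook for compound 3

A few compounds are considered here, and "the series" means these few. Any claim that something is new, unique, unknown or untested is made for them only; others in the source may bear on it.

Measured so far in an ADME assay on HepG2 cells (Homo sapiens) for inhibition, with a stated time of 48 h; a lower number here means that less compound is needed, a higher number that more compound is needed for the effect:
Compound 1 `CC(C(=O)N1CCCCCC1)N1CCN(S(=O)(=O)c2ccc(C(C)(C)C)cc2)CC1` reaches only the limit of this assay, > 40000 nM.
Compound 2 `CC(C(=O)N1CCc2ccccc2C1C)N1CCN(S(=O)(=O)c2ccc(C(C)(C)C)cc2)CC1` gives 28000 nM in this assay.

Compound 2 holds the only number shown in this assay; the other value is a limit. Within the data shown here, the one measured step runs an at least 1.4-fold lower number from compound 1 to compound 2 (0.15 log units; that floor lies within the scatter), and its floor is set by the limit of > 40000 nM in this assay, at which 1 of the 2 values shown sits, so the true size of that step is open.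

Compound 3 `CC(C(=O)N1CCc2cccnc2C1)N1CCN(S(=O)(=O)c2ccc(C(C)(C)C)cc2)CC1` differs from compound 2 in a single place: a group of 10 heavy atoms (8 carbon, 2 nitrogen; one six-membered non-aromatic ring with 1 hetero atom, one six-membered aromatic ring with 1 hetero atom) in place of a group of 11 heavy atoms (10 carbon, 1 nitrogen; one six-membered non-aromatic ring with 1 hetero atom, one six-membered aromatic ring of carbon only), on a carbonyl carbon. Among the measured compounds shown here, no measured step covers this change, and the only step known is bounded below by a limit and may lie within the scatter. No step beyond the scatter is therefore expected from compound 2 to compound 3 in this assay, with a wide range to either side. For compound 3 the expected step is a 1.1-fold higher number from compound 2 to compound 3 (0.03 log units; within the scatter), giving an estimate of 30000 nM, between 12000 nM and 80000 nM.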

Compound 3, half-maximal effective concentration: > 40000 nM
Compound 3 gave a limit, no number (the forecaster's own chance of this, stated with the estimate: 40%); middle value at least 1.3-fold (0.12 log units) from the limit.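

In this assay, among these compounds, the exchange of 1-methyl-1,2,3,4-tetrahydroisoquinolin-2-yl for the group with a hetero atom in its aromatic ring gives an at least 1.4-fold higher number from compound 2 to compound 3 (0.15 log units; that floor lies within the scatter) and leaves compound 2 as the only compound with a number. Compound 3 gives a limit and not a number, so the step from compound 2 has only a floor, and the steps between limits cannot be read. Both steps that touch compound 2 therefore stay open in size: the limit of > 40000 nM in this assay, at which 2 of the 3 values shown sit.

On these data alone, whether the hetero atom in the aromatic ring or the absence of the methyl group matters more stays open, as the two changes come together in one step. Also open, as far as these compounds go, is what this assay returns for a group carrying an amine or a carboxylic acid on this carbonyl carbon.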